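The source may hold more compounds than are shown below. What is called first, only, known or untested is meant among the compounds shown, and "the series" means these compounds.

Among the compounds with values here, compound 3 `COc1ccc(-c2c(C=O)c3cc(C#N)c(C#N)cc3n2OC)cc1` gives the lowest number so far in an assay on isolated protein for inhibition of Amine oxidase [flavin-containing] A (Homo sapiens), read by fluorescence and spectrophotometry, with a stated time of 20 min; a lower number here means a stronger inhibitor, a higher number a weaker inhibitor: compound 3 gives 147 nM. Compound 2 `COn1c(-c2ccc(C)cc2)c(C=O)c2cc(C#N)c(C#N)cc21` gives 405 nM in this assay, and the change a 2.8-fold lower number from compound 2 to compound 3 (0.44 log units; beyond the scatter) went beyond the scatter. Compound 1 `N#Cc1cc2cc(-c3ccccc3)n(O)c2cc1C#N` gives 6920 nM in this assay, far above compound 3. Compound 4 `COc1ccc(-c2c(CO)c3cc(C#N)c(C#N)cc3n2OC)cc1` differs from compound 3 in one place: hydroxymethyl in place of formyl on an aromatic carbon. Within the data shown here, none of the measured steps touches this part of the molecule, so there is no direct guide; the expected step of a 1.5-fold higher number from compound 3 to compound 4 (0.18 log units; within the scatter) in this assay is therefore small and could go either way. Compound 4 is estimated at 220 nM in this assay, with a plausible range from 70 nM to 700 nM.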

Compound 4, half-maximal inhibitory concentration: 1130 nM
For compound 4 the middle estimate is 5.1-fold (0.71 log units) below the measured one; the whole stated range lies below it.
By their numbers in this assay, from the lowest: compound 3; then compound 2; then compound 4; then compound 1.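

At this aromatic carbon, hydroxymethyl in place of formyl gives a 7.7-fold higher number from compound 3 to compound 4 (0.89 log units; beyond the scatter) in this assay, so the number responds to what this position carries, even though both groups have the same heavy-atom count. The change removes a double bond outside aromatic rings and adds a hydrogen-bond donor, and the data cannot separate these two differences. Nothing available gives a reason for this step.

Open, as far as these compounds go, is how a carboxylic acid, an amine or a longer chain at this carbon would compare with formyl. Also open, from the compounds shown here alone, is whether this step would repeat with the 4-methoxyphenyl group replaced.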